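A few compounds are considered here, and "the series" means these few. Any claim that something is new, unique, unknown or untested is made for them only; others in the source may bear on it.

Measured so far:
- compound 1 `COc1cc2c(Oc3ccc(NC(=O)N/N=C/c4ccc([N+](=O)[O-])cc4)cc3F)ccnc2cc1OCCCN1CCCC1`: 470 nM
- compound 2 `COc1cc2c(Oc3ccc(NC(=O)N/N=C/c4ccc(C(F)(F)F)cc4)cc3F)ccnc2cc1OCCCN1CCCC1`: 1300 nM

Both were tested in a functional assay on MKN-45 cells (Homo sapiens) for cytotoxicity, read by MTT assay, with a stated time of 72 h; on this read-out higher numbers stand for weaker inhibition and lower numbers for stronger inhibition. Within the data shown here, of the two numbers, compound 1 has the lower one, and the only comparison available is a 2.8-fold higher number from compound 1 to compound 2 (0.44 log units; beyond the scatter), a swap of the substituent on the far aromatic ring. Compound 3 `COc1cc2c(Oc3ccc(NC(=O)N/N=C/c4ccc([N+](=O)[O-])cc4)cc3F)ccnc2cc1OCCCN1CCC(C)CC1` is not yet measured. It comes from compound 1 by 4-methylpiperidin-1-yl in place of pyrrolidin-1-yl on a saturated chain carbon, three bonds along the chain from an oxygen on an aromatic ring; the nitro group and everything else in compound 1 are kept. Among the measured compounds shown here, no measured step touches this end of the molecule: the single known step concerns the aromatic substituent and says nothing about the ring at the end of the chain. Without such a comparison, no change beyond the scatter is expected. For compound 3 the expected step is no change at the digits printed from compound 1 to compound 3 (within the scatter). Compound 3 is therefore expected near 470 nM, with a range from 200 nM to 1100 nM.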

Compound 3, half-maximal inhibitory concentration: 420 nM
Compound 3: the middle estimate sits 1.1-fold (0.05 log units) above what was measured; the measured number falls inside the stated range.
By their numbers in this assay, from the lowest: compounds 3 and 1 (each within the scatter of the next); then compound 2.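

In this assay, among these compounds, the end of the side chain can now be compared for the first time: there is a 1.1-fold lower number from compound 1 to compound 3 (0.05 log units; within the scatter) when 4-methylpiperidin-1-yl replaces pyrrolidin-1-yl. At this place, a six-membered ring bearing a methyl group can therefore stand in for a five-membered ring without a change beyond the scatter, whereas the earlier step concerned only the substituent on the far aromatic ring. Nothing measured here explains this result.

On these data alone, it remains open whether a morpholine ring, with an oxygen in the ring, or a dimethylamino group at the chain end, or a longer chain, would also leave the number unchanged. As far as these compounds go, it is also open whether the same ring swap would read alike in compound 2, which carries trifluoromethyl instead of nitro.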